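This account rests on a few compounds, and the source may have more. Where it says the series, first, only, none or still open, it means among the compounds named here.

In an ADME assay on Caco-2 cells (Homo sapiens) for permeability (on this read-out lower numbers stand for lower permeability and higher numbers for higher permeability), compound 1 `Nc1cc(-c2cccc(-n3ccc4cc(C5CC5)cc(F)c4c3=O)c2CO)nc(Nc2cnn(C3CC3)c2)n1` gives 6.9 10^-6 cm/s.
In this assay compound 2 `CC(C)(C)n1cc(Nc2nc(N)cc(-c3cccc(-n4ccc5cc(C6CC6)cc(F)c5c4=O)c3CO)n2)cn1` gives 5.7 10^-6 cm/s.
In this assay compound 3 `Nc1cc(-c2cccc(-n3ccc4cc(C5CC5)cc(F)c4c3=O)c2CO)nc(Nc2cnn(C3(CO)CC3)c2)n1` gives 0.7 10^-6 cm/s.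

Compound 3 stands lowest of the three numbers in this assay, beyond the scatter below both compound 2 and compound 1. Compound 4 `Nc1cc(-c2cccc(-n3ccc4cc(C5CC5)cc(F)c4c3=O)c2CO)nc(Nc2cnn(CC3CC3)c2)n1` differs from compound 3 in one place: cyclopropylmethyl in place of 1-(hydroxymethyl)cyclopropyl on an aromatic nitrogen. Going by the values given here, two measured steps bear on this change. Going the other way, a 9.9-fold lower number from compound 1 to compound 3 (0.99 log units; beyond the scatter), and an 8.1-fold lower number from compound 2 to compound 3 (0.91 log units; beyond the scatter); in both the group carrying the hydroxymethyl gave the lower number. Compound 4 keeps a three-membered carbon ring but loses the hydroxymethyl, so a rise of similar size back toward compound 1 and compound 2 is expected, an 8.6-fold higher number from compound 3 to compound 4 (0.93 log units; beyond the scatter). Compound 4 is therefore estimated at 6 10^-6 cm/s, with a range from 2.5 10^-6 cm/s to 12 10^-6 cm/s.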

Compound 4, apparent permeability: 6.1 10^-6 cm/s
Beside the measured number, compound 4's estimate is 1.0-fold (0.01 log units) below it; measured number inside the range.
By their numbers in this assay, from the lowest: compound 3; then compounds 2, 4 and 1 (each within the scatter of the next).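

In this assay, the change from 1-(hydroxymethyl)cyclopropyl to cyclopropylmethyl keeps the three-membered carbon ring and loses the hydroxymethyl, and gives (an 8.7-fold higher number from compound 3 to compound 4 (0.94 log units; beyond the scatter)). Cyclopropylmethyl also matches tert-butyl (a 1.1-fold higher number from compound 2 to compound 4 (0.03 log units; within the scatter)) and cyclopropyl (a 1.1-fold lower number from compound 1 to compound 4 (0.05 log units; within the scatter)), so across these four compounds only the group carrying the hydroxymethyl stands apart. Nothing measured here explains this difference. The compounds shown leave open whether an amine, a carboxylic acid or a longer chain ending in hydroxyl on this aromatic nitrogen would give a number as low as that of compound 3.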